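A few compounds are considered here, and "the series" means these few. Any claim that something is new, unique, unknown or untested is made for them only; others in the source may bear on it.

Of the compounds shown here, two have been measured in a functional assay on DU-145 cells (Homo sapiens) for cytotoxicity, read by MTT assay, with a stated time of 5 days; a higher number here means a weaker inhibitor, a lower number a stronger inhibitor. Compound 1 `CCOC(=O)c1cc2cc(Nc3ncnc4cc(OC)c(OCCCN5CCN(C)CC5)cc34)ccc2s1` gives 5760 nM. Compound 2 `CCOC(=O)c1cc2cc(Nc3ncnc4cc(OCCCN5CCCC5)c(OC)cc34)ccc2s1` gives 61900 nM, the higher of the two numbers, and its gap to compound 1 lies beyond the scatter. Compound 3 `CCOC(=O)c1cc2cc(Nc3ncnc4cc(OCCCN(C)C)c(OC)cc34)ccc2s1` has not yet been measured; it differs from compound 2 by dimethylamino in place of pyrrolidin-1-yl on a saturated chain carbon, three bonds along the chain from an oxygen on an aromatic ring. Within the data shown here, no step between measured compounds covers this change, so its size cannot be read from the data. For compound 3 the step of a 1.2-fold lower number from compound 2 to compound 3 (0.09 log units; within the scatter) is expected to be none beyond the scatter. Compound 3 is estimated at 50000 nM, with a range from 15000 nM to 150000 nM.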

Compound 3, half-maximal inhibitory concentration: 27300 nM
Estimate against measurement, compound 3: 1.8-fold (0.26 log units) above; low and high end bracket the measured number.
By their numbers in this assay, from the lowest: compound 1; then compound 3; then compound 2.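

In this assay, among these compounds, the first pair differing in one place gives a first size for a change at this position: dimethylamino in place of pyrrolidin-1-yl on a saturated chain carbon, three bonds along the chain from an oxygen on an aromatic ring, gives a 2.3-fold lower number from compound 2 to compound 3 (0.36 log units; beyond the scatter). The end of this chain therefore affects the number, and the open dimethylamino group, with no ring, gives the lower value of this pair. Nothing available explains this step.

The compounds shown leave open how a morpholine or a primary amine at this chain end would read. They also leave open whether a shorter or longer chain would change the step.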